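The compounds below may be only part of what the source reports. "The series", "measured", "known", "first", "only" and "open" are said of these compounds alone.

Measured so far in a functional assay on LNCaP cells (Homo sapiens) for cytotoxicity, read by MTT assay, with a stated time of 72 h; a lower number here means a stronger inhibitor, a higher number a weaker inhibitor:
Compound 1 `Nc1cccc(Nc2c(C(=O)NCc3ccc(F)cc3)nc(Br)c3cccnc23)c1` gives 8000 nM.
Compound 2 `O=C(NCCCNc1c(C(=O)NCc2ccc(F)cc2)nc(Br)c2cccnc12)c1ccccc1` gives only a limit of the assay, > 10000 nM.
Compound 3 `CNCCCNc1c(C(=O)NCc2ccc(F)cc2)nc(Br)c2cccnc12` gives 8000 nM.

Compound 1 stands level with compound 3 at the digits shown, since no change at the digits printed from compound 1 to compound 3 (within the scatter). Of compound 2 only a limit is known (the limit of > 10000 nM in this assay, at which 1 of the 3 values shown sits). The step of an at least 1.2-fold lower number from compound 2 to compound 3 (0.09 log units; that floor lies within the scatter) has a floor that lies within the scatter, so no real difference between those two can be claimed.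

The compound now in question, compound 4 `NCCCCCCNc1c(C(=O)NCc2ccc(F)cc2)nc(Br)c2cccnc12`, differs from compound 1 in one place: 6-aminohexyl in place of 3-aminophenyl on a nitrogen on an aromatic ring. The shared core, the amide and the bromine are untouched. The step from compound 1 to compound 3 is the closest guide, since it also traded the 3-aminophenyl on the same nitrogen for a flexible amine-bearing chain, and it brought no change within the scatter. Among the measured compounds shown here, the step from compound 2 to compound 3 is the only other measured step, and its floor also lies within the scatter. Nothing measured here suggests a chain in this position shifts potency.

Compound 4 is therefore expected to show no change at the digits printed from compound 1 to compound 4 (within the scatter), no step beyond the scatter. Compound 4 is estimated at 8000 nM, with a likely range from 3000 nM to 20000 nM.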

Compound 4, half-maximal inhibitory concentration: 8000 nM
For compound 4 middle estimate and measured number coincide at the digits printed, within the range that was stated.
By their numbers in this assay, from the lowest: compounds 1, 3 and 4 (each within the scatter of the next). At a limit, above all of these: compound 2.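

In this assay, replacing the ring of 3-aminophenyl with the ring-free, flexible 6-aminohexyl on a nitrogen on an aromatic ring gives no change at the digits printed from compound 1 to compound 4 (within the scatter), so at this level of activity an aromatic ring in this group is not required. Compound 3 had already hinted at this, but its chain also carries a methyl on its amine; putting 3-aminopropyl in place of methylamino gives no change at the digits printed from compound 3 to compound 4 (within the scatter), so neither the extra chain length nor the free end amine separates these two compounds. Putting 3-aminopropyl in place of benzamido gives an at least 1.2-fold lower number from compound 2 to compound 4 (0.09 log units; that floor lies within the scatter), so no real difference can be claimed there either, and the number on the compound 2 side is only a limit: the limit of > 10000 nM in this assay, at which 1 of the 4 values shown sits.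

All of these compounds keep a nitrogen in the group at this position, so it remains open whether a chain ending in a hydroxyl or a carboxylic acid, or a chain with no end group at all, would move the number beyond the scatter. From the compounds shown here alone, it also remains open whether a much longer chain, or a piperazine ring in its place, would do so.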